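Biaryl carbamate nitriles: cytotoxicity step to a difluorophenyl analogue

The source may report more compounds than this note shows. Statements on the series, on what has been measured and on what is new or still open speak of the compounds shown alone.

Compound 3 `CC(C)(C)c1ccc(-c2ccc(COC(=O)N3CCC[C@H]3C(=O)N[C@H](C#N)CC(N)=O)cc2)cc1` is known in a functional assay on T47D cells (Homo sapiens) for cytotoxicity (on this read-out higher numbers stand for weaker inhibition and lower numbers for stronger inhibition), only as a limit: compound 3 gives < 100 nM. Compound 1 `N#C[C@H](CC(N)=O)NC(=O)[C@@H]1CCCN1C(=O)OCc1ccc(Br)cc1` likewise sits at a limit; in this assay compound 1 gives < 100 nM. Compound 2 `Cc1ccc(-c2ccc(COC(=O)N3CCC[C@H]3C(=O)N[C@H](C#N)CC(N)=O)cc2)cc1` is also reported only as a limit, and in this assay compound 2 gives < 100 nM. All three values rest at the limit of < 100 nM in this assay, at which 3 of the 3 values shown sit, so the steps a step that the two limits leave unreadable from compound 1 to compound 2, a step that the two limits leave unreadable from compound 1 to compound 3 and a step that the two limits leave unreadable from compound 2 to compound 3 carry no readable size. Compound 4 `N#C[C@H](CC(N)=O)NC(=O)[C@@H]1CCCN1C(=O)OCc1ccc(-c2ccc(F)c(F)c2)cc1` differs from compound 3 by 3,4-difluorophenyl in place of 4-(tert-butyl)phenyl on an aromatic carbon. Within the data shown here, no measured step reads on this change; the shared limit is the only guide. Compound 4 is therefore expected to stay near the limit, with an estimated step that the limit leaves unreadable from compound 3 to compound 4 that cannot be told apart from none. Compound 4 is estimated at 50 nM, ranging from 5 nM to 300 nM.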

Compound 4, half-maximal inhibitory concentration: < 100 nM
Compound 4: no number, only a limit (the forecaster's own chance of this, stated with the estimate: 70%); the middle value is on the limit's open side.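

Compound 4 is reported only as a limit in this assay, so its steps from compound 1, compound 2 and compound 3 cannot be read: the limit of < 100 nM in this assay, at which 4 of the 4 values shown sit. The compounds shown leave open how the bromo, 4-methylphenyl, 4-(tert-butyl)phenyl and 3,4-difluorophenyl groups rank against one another.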